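A few compounds are considered here, and "the series" means these few. Any claim that something is new, unique, unknown or untested is made for them only; others in the source may bear on it.

The measured compounds, with their results in a functional assay on Z-138 cells (Homo sapiens) for inhibition, read by luminescence and CellTiter-Glo, with a stated time of 72 h; a higher number here means a weaker inhibitor, a lower number a stronger inhibitor:

Compound 1 `O=C(CCl)Nc1ccc(Cn2nc(-c3ccc(Oc4ccccc4)cc3)cc2CO)cc1`: 400 nM
Compound 2 `C=CC(=O)Nc1ccc(Cn2nc(-c3ccc(Oc4ccccc4)cc3)cc2CO)cc1`: 6800 nM
Compound 3 `C=CC(=O)Nc1cccc(Cn2nc(-c3ccc(Oc4ccccc4)cc3)cc2CO)c1`: 6000 nM

Compound 2 and compound 3 share the same atoms joined differently; the difference between their two cores is not broken down here. Their two values lie within the usual scatter of each other, so nothing can be said about an order between them.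

Compound 1 is obtained from compound 2 by one change, (chloromethyl in place of vinyl on a carbonyl carbon). This change gave a 17-fold lower number from compound 2 to compound 1 (1.23 log units; beyond the scatter), a step well beyond the scatter and the only large movement among the three measured compounds.

Compound 4 `O=C(CCl)Nc1cccc(Cn2nc(-c3ccc(Oc4ccccc4)cc3)cc2CO)c1` has not yet been measured in this assay. It is obtained from compound 3 by the same change, (chloromethyl in place of vinyl on a carbonyl carbon), made on the core of compound 3 rather than that of compound 2; the surroundings of the changed carbonyl carbon read the same in both cases.

Since compound 3 gives 6000 nM, close to compound 2, the step from compound 3 to compound 4 is expected to resemble the earlier one, and compound 4 is estimated at 400 nM. Going by the values given here, the expected step is a 15-fold lower number from compound 3 to compound 4 (1.18 log units; beyond the scatter), resting on the single measured instance of this change. Because that rests on one pair only, a wide range from 150 nM to 1500 nM is estimated for compound 4.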

Compound 4, half-maximal inhibitory concentration: 400 nM
The estimate for compound 4 equals the measured number at the digits printed, within the range that was stated.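

In this assay, chloromethyl in place of vinyl on a carbonyl carbon gave a 15-fold lower number from compound 3 to compound 4 (1.18 log units; beyond the scatter), and this step agrees with the one seen earlier on the other core: the same change on two cores in this assay, a 17-fold lower number (1.23 log units; beyond the scatter) from compound 2 to compound 1 and a 15-fold lower number (1.18 log units; beyond the scatter) from compound 3 to compound 4, 1.1-fold (0.05 log units) apart, within the scatter of two such steps. Within this series, then, the change carried from one core to the other with its size intact, even though the two cores hold the same atoms joined differently. Going by these compounds alone, this rests on only two pairs of closely related compounds, however, and it shows neither why the number falls nor whether a step of this size would appear on a core further removed from these two.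

The compounds shown leave open whether the step is particular to chloromethyl or would also appear with bromomethyl, a plain methyl or a longer chain on the same carbonyl carbon. They also leave open whether a core carrying an amine or a carboxylic acid would respond to the change from vinyl to chloromethyl in the same way.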